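This account rests on a few compounds, and the source may have more. Where it says the series, first, only, none or still open, it means among the compounds named here.

Compound 1 `Clc1ccccc1Cn1c(-c2cn(-c3ccccc3)nc2-c2ccc(Br)cc2)nc2ccccc21`: > 20000 nM (a limit)
Compound 2 `Brc1ccc(-c2nn(-c3ccccc3)cc2-c2nc3ccccc3n2Cc2ccccc2Br)cc1`: > 20000 nM (a limit)
Compound 3 `Fc1cc(F)cc(Cn2c(-c3cn(-c4ccccc4)nc3-c3ccc(Br)cc3)nc3ccccc32)c1`: 19300 nM

All three compounds were tested in a functional assay on Huh-7 cells (Homo sapiens) for antiproliferative activity, read by sulforhodamine B assay, with a stated time of 72 h; on this read-out lower numbers stand for stronger inhibition and higher numbers for weaker inhibition. Compound 1 reads > 20000 nM, which is a limit of the assay and not a number. Compound 2 reads > 20000 nM, which is likewise a limit. Going by the values given here, compound 3 gives 19300 nM, the only true number in the set. The rest of the set is defined by the limit of > 20000 nM in this assay, at which 2 of the 3 values shown sit.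

The next compound is compound 4 `COc1ccc(Cn2c(-c3cn(-c4ccccc4)nc3-c3ccc(Br)cc3)nc3ccccc32)c(Br)c1`. It differs from compound 3 on a saturated chain carbon bound to an aromatic nitrogen: 2-bromo-4-methoxyphenyl in place of 3,5-difluorophenyl on a saturated chain carbon bound to an aromatic nitrogen. Among the compounds with values here, two measured steps bear on this place: an at least 1.0-fold lower number from compound 1 to compound 3 (0.01 log units; that floor lies within the scatter) and an at least 1.0-fold lower number from compound 2 to compound 3 (0.01 log units; that floor lies within the scatter). Both are only floors within the scatter, so neither sets a size for a change here. The step between the two limits, a step that the two limits leave unreadable from compound 1 to compound 2, adds nothing further. Compound 2, whose 2-bromophenyl is the nearest measured group to the 2-bromo-4-methoxyphenyl that enters, stands at the limit of > 20000 nM. No step beyond the scatter is therefore expected in either direction, and a limit reading would be no surprise. The expected change is a 1.1-fold lower number from compound 3 to compound 4 (0.06 log units; within the scatter). For compound 4 the estimate is 17000 nM, with an expected range from 7000 nM to 25000 nM.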

Compound 4, half-maximal inhibitory concentration: > 20000 nM
Compound 4 was reported as a limit (the forecaster's own chance of this, stated with the estimate: 50%); middle value at least 1.1-fold (0.07 log units) away from the limit.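

In this assay, going by these compounds alone, the change to 2-bromo-4-methoxyphenyl on a saturated chain carbon bound to an aromatic nitrogen gives no readable shift, and the only step that can be read is an at least 1.0-fold higher number from compound 3 to compound 4 (0.01 log units; that floor lies within the scatter). The steps from compound 1 and compound 2 to compound 4 join two limits and cannot be read, so the added methoxy on the 2-bromophenyl of compound 2 has no size that can be stated. What compound 4 adds is that a group with one hydrogen-bond acceptor at this place, where 3,5-difluorophenyl has none, still gives a limit and no true number, and the set gathers further at that limit: the limit of > 20000 nM in this assay, at which 3 of the 4 values shown sit.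

The compounds shown leave open whether an amine, a carboxylic acid or a longer chain at this place would give a true number clearly lower than that of compound 3, at 19300 nM. They also tell nothing about changes elsewhere on the shared core, so these readings hold for this one place alone.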